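The compounds below may be only part of what the source reports. "The series", "measured", "known", "first", "only" and "open" are said of these compounds alone.

Compound 3, `Cc1cn([C@@H]2O[C@H](CO[Si](C)(C)C(C)(C)C)[C@@]3(OS(=O)(=O)C=C3NC(=O)c3ccccc3)[C@H]2O[Si](C)(C)C(C)(C)C)c(=O)n(C)c1=O`, belongs to a small group of compounds that share one core and differ only in the group attached to an amine nitrogen whose other neighbour is a double-bonded ring carbon. In a functional assay on HEL cells (Homo sapiens) for cytotoxicity, read by microscopy (on this read-out higher numbers stand for lower toxicity in this test and lower numbers for higher toxicity in this test), compound 1, `CCOC(=O)NC(=O)NC1=CS(=O)(=O)O[C@@]12[C@@H](CO[Si](C)(C)C(C)(C)C)O[C@@H](n1cc(C)c(=O)n(C)c1=O)[C@@H]2O[Si](C)(C)C(C)(C)C`, gives 16000 nM. Compound 2, `Cc1cn([C@@H]2O[C@H](CO[Si](C)(C)C(C)(C)C)[C@@]3(OS(=O)(=O)C=C3NC(N)=O)[C@H]2O[Si](C)(C)C(C)(C)C)c(=O)n(C)c1=O`, gives 16000 nM in this assay. For compound 3 this assay returned only a limit, >= 3200 nM, so where it truly stands is not pinned down. Compound 4, `Cc1cn([C@@H]2O[C@H](CO[Si](C)(C)C(C)(C)C)[C@@]3(OS(=O)(=O)C=C3NCCC(=O)OCc3ccccc3)[C@H]2O[Si](C)(C)C(C)(C)C)c(=O)n(C)c1=O`, has not yet been measured. It differs from compound 3 as follows: 2-(benzyloxycarbonyl)ethyl in place of benzoyl on an amine nitrogen. Both the leaving and the entering group carry one six-membered aromatic ring of carbon only. Of the measured steps, no change at the digits printed from compound 1 to compound 2 (within the scatter) stays within the scatter, while a step that the limit leaves unreadable from compound 1 to compound 3 and a step that the limit leaves unreadable from compound 2 to compound 3 cannot be sized, as the limit of >= 3200 nM in this assay, at which 1 of the 3 values shown sits, shows. Among the measured compounds shown here, no measured step therefore points to a movement beyond the scatter. Compound 4 is expected to give 8000 nM in this assay, with a range from 3200 nM to 32000 nM. The step that the limit leaves unreadable from compound 3 to compound 4 is thus estimated to be none beyond the scatter.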

Compound 4, minimum cytotoxic concentration: >= 400000 nM
Compound 4 ended at the assay's limit; the forecaster's own chance of this, stated with the estimate: 50%; middle value at least 50-fold (1.69 log units) from the limit.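

Among the compounds shown here, on an amine nitrogen whose other neighbour is a double-bonded ring carbon, the change to 2-(benzyloxycarbonyl)ethyl gives an at least 25-fold higher number from compound 2 to compound 4 (1.39 log units; beyond the scatter) and an at least 25-fold higher number from compound 1 to compound 4 (1.39 log units; beyond the scatter) in this assay, whereas the only earlier readable step stayed within the scatter. This shows that a change at this position can move the read-out substantially towards lower toxicity in this test, although the full size of both steps remains unknown, since compound 4 gave only a limit: the limit of >= 400000 nM in this assay, at which 1 of the 4 values shown sits. The steps linking compound 3 with compound 1, compound 2 and compound 4 cannot be read, since compound 3 also gave only a limit: the limit of >= 3200 nM in this assay, at which 1 of the 4 values shown sits.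

The compounds shown leave open which part of 2-(benzyloxycarbonyl)ethyl goes with the higher number. A plain ethyl group, or a carboxylic acid in place of the benzyl ester, on this nitrogen would help separate the chain from the ester.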